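Swapping Trifluoromethoxy for Fluoro on a Shared Core

The source may report more compounds than this note shows. Statements on the series, on what has been measured and on what is new or still open speak of the compounds shown alone.

Measured so far in a functional assay on MCF7 cells (Homo sapiens) for inhibition, read by sulforhodamine B assay, with a stated time of 72 h; a lower number here means a stronger inhibitor, a higher number a weaker inhibitor:
- compound 1 `CC(c1ccc(-c2ccccc2)c(F)c1)c1nnc2n1N=C(c1ccc(OC(F)(F)F)cc1)CS2`: 4800 nM
- compound 2 `COc1ccc2cc(C(C)c3nnc4n3N=C(c3ccc(C)cc3)CS4)ccc2c1`: 11000 nM
- compound 3 `CC(C)Cc1ccc(C(C)c2nnc3n2N=C(c2ccc(F)cc2)CS3)cc1`: 8900 nM

All three compounds share one core and differ only in the groups hung on it. Among them compound 1 gives the lowest number, 4800 nM, in this assay. Its gap to compound 3, which gives 8900 nM, lies within the usual scatter of the measurement, so the two cannot be ranked against each other. Its gap to compound 2, which gives 11000 nM, lies just beyond that scatter.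

Compound 4 `CC(c1ccc(-c2ccccc2)c(F)c1)c1nnc2n1N=C(c1ccc(F)cc1)CS2` has not yet been measured. It keeps everything of compound 1 except one group: fluoro in place of trifluoromethoxy on an aromatic carbon. Seen one bond further out, the change reads 4-(trifluoromethoxy)phenyl to 4-fluorophenyl, at a position para to a large group.

Going by the values given here, no pair of measured compounds differs in only this place, so there is no measured step to lean on. A small step is expected, likely toward a somewhat higher number and not clearly beyond the scatter, and the expected step is a 1.4-fold higher number from compound 1 to compound 4 (0.13 log units; within the scatter). Compound 4 is therefore estimated at 6500 nM, with a range from 2500 nM to 16000 nM.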

Compound 4, half-maximal inhibitory concentration: 8100 nM
Beside the measured number, compound 4's estimate is 1.2-fold (0.10 log units) below it; the measured number falls inside the stated range.
By their numbers in this assay, from the lowest: compounds 1, 4, 3 and 2 (each within the scatter of the next, the first and the last beyond it).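

In this assay, going by these compounds alone, this pair gives the first direct reading of the change, a 1.7-fold higher number from compound 1 to compound 4 (0.23 log units; within the scatter), so the two compounds cannot be ranked against each other. With everything else in compound 1 held fixed, trifluoromethoxy, with its 5 heavy atoms and 1 hydrogen-bond acceptor, gives way to a single fluorine on the same aromatic carbon without a difference that this measurement can resolve. No supporting data explain this reading.

On these data alone, whether an amine, a carboxylic acid or a longer chain such as butoxy at this place would give a step beyond the scatter remains open. Also open, as far as these compounds go, is whether the same swap would read alike with the other groups of compound 2 or compound 3 on the shared core.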